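This account rests on a few compounds, and the source may have more. Where it says the series, first, only, none or still open, it means among the compounds named here.

Compound 1 `COc1cc[nH]c1/C=C1\C(=O)Nc2ccc([N+](=O)[O-])c(N3CC[C@@H](N)C3)c21` gives < 10 nM in a functional assay on MDA-MB-435 cells (Homo sapiens) for antiproliferative activity, read by MTT assay, with a stated time of 5 days (a lower number here means a stronger inhibitor, a higher number a weaker inhibitor), which is a limit of the assay. Compound 2 `COc1cc[nH]c1/C=C1\C(=O)Nc2ccc([N+](=O)[O-])c(N3CCC(N)CC3)c21` gives < 10 nM, likewise a limit. Compound 3 `COc1cc[nH]c1/C=C1\C(=O)Nc2ccc([N+](=O)[O-])c(N3CCCC(O)C3)c21` gives 250 nM.

Among the compounds with values here, compound 3 thus holds the only number in the set; the other two values are limits (the limit of < 10 nM in this assay, at which 2 of the 3 values shown sit). Compound 4 `COc1cc[nH]c1/C=C1\C(=O)Nc2ccc([N+](=O)[O-])c(N[C@H]3CC[C@H](O)C3)c21` differs from compound 3 by (3-hydroxycyclopentyl)amino in place of 3-hydroxypiperidin-1-yl on an aromatic carbon. Within the data shown here, two measured steps bear on this: an at least 25-fold higher number from compound 1 to compound 3 (1.39 log units; beyond the scatter) and an at least 25-fold higher number from compound 2 to compound 3 (1.39 log units; beyond the scatter); in both an amino substituent leaves and a hydroxyl-bearing ring enters, and both are large. Compound 4 keeps the hydroxyl and adds a second hydrogen-bond donor, so no step beyond the scatter is expected, no change at the digits printed from compound 3 to compound 4 (within the scatter). Compound 4 is therefore estimated at 250 nM, within 50 nM to 1200 nM.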

Compound 4, half-maximal inhibitory concentration: 1000 nM
The estimate for compound 4 lay 4.0-fold (0.60 log units) below the measured number; the range from low to high includes it.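

In this assay, the same atoms rejoined as (3-hydroxycyclopentyl)amino in place of 3-hydroxypiperidin-1-yl give a 4.0-fold higher number from compound 3 to compound 4 (0.60 log units; beyond the scatter), so on this aromatic carbon, ortho to a nitro group, the value depends on more than the hydroxyl being kept. The gap to the amino-bearing rings widens to an at least 100-fold higher number from compound 2 to compound 4 (2.00 log units; beyond the scatter) and an at least 100-fold higher number from compound 1 to compound 4 (2.00 log units; beyond the scatter). Both of these steps start from a limit, not a number: the limit of < 10 nM in this assay, at which 2 of the 4 values shown sit.

Open, going by these compounds, is how a 3-aminopiperidin-1-yl or (3-aminocyclopentyl)amino group would read, which would separate the amine from the way the ring is attached. On these data alone, the true distance between the amino compounds and the hydroxyl compounds also stays open.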